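A few compounds are considered here, and "the series" means these few. Any claim that something is new, unique, unknown or untested is made for them only; others in the source may bear on it.

Measured compounds:
Compound 1 `Oc1ccc(/C=C/c2ccccc2O)cc1`: 22 ug/mL in a functional assay on HT-29 cells (Homo sapiens) for inhibition, read by MTT assay, with a stated time of 2 days; a higher number here means a weaker inhibitor, a lower number a stronger inhibitor
Compound 2 `Nc1ccccc1/C=C/c1ccc(O)cc1`: > 100 ug/mL, which is a limit of the assay and not a number
Compound 3 `COc1cccc(/C=C/c2ccc(O)cc2)c1`: 26 ug/mL

Two of these compounds differ in one place only. The change from compound 1 to compound 2 is amino in place of hydroxy on an aromatic carbon, and it made an at least 4.5-fold higher number from compound 1 to compound 2 (0.65 log units; beyond the scatter). The difference between the cores of compound 1 and compound 3 is not broken down here; their two values sit within the usual scatter of each other, so no order between them is claimed.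

Compound 4 `COc1cccc(/C=C/c2ccc(N)cc2)c1` has not yet been measured in this assay. It differs from compound 3 by amino in place of hydroxy on an aromatic carbon. This is the same kind of change as the measured one, though the place differs: in compound 2 the amino sits ortho to a group of 9 heavy atoms, whereas in compound 4 it sits para to a large group. The expectation for compound 4 is a weakening of a size comparable to the earlier step, resting on an at least 4.5-fold higher number from compound 1 to compound 2 (0.65 log units; beyond the scatter). Compound 4 is therefore expected at about 90 ug/mL, most likely between 30 ug/mL and 200 ug/mL. The expected step is a 3.5-fold higher number from compound 3 to compound 4 (0.54 log units; beyond the scatter).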

Compound 4, half-maximal inhibitory concentration: 16.1 ug/mL
Compound 4: middle estimate off by 5.6-fold (0.75 log units), on the high side, and the stated range ends above it.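

In this assay, amino in place of hydroxy on the core of compound 3 gives a 1.6-fold lower number from compound 3 to compound 4 (0.21 log units; within the scatter), so no change in inhibition is claimed for this pair. The earlier step on the other core was a clear weakening, so the same swap does not carry over unchanged from one core to the other: the same change on two cores in this assay, an at least 4.5-fold higher number (0.65 log units; beyond the scatter) from compound 1 to compound 2 and a 1.6-fold lower number (0.21 log units; within the scatter) from compound 3 to compound 4, at least 7.3-fold (0.86 log units) apart, beyond the scatter of two such steps. These two pairs do not show why the cores respond differently, and the earlier step rests on compound 2, whose > 100 ug/mL is a limit of the assay and not a number.

As far as these compounds go, whether the split follows the place of the amino group or some other difference between the two cores stays open. Also open, from the compounds shown here alone, is how other groups would behave in the same place on the core of compound 3, such as a methylamino group, a carboxylic acid or a longer chain.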